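Replacing a Substituted Benzyl with Hexyl in Compound 4

This account rests on a few compounds, and the source may have more. Where it says the series, first, only, none or still open, it means among the compounds named here.

- compound 1 `CC#CCn1c(N2CCC[C@@H](N)C2)cc(=O)n(Cc2cc(Br)c(OC)c(OC)c2)c1=O` - 2.38
- compound 2 `COc1cc(Cn2c(=O)cc(N3CCC[C@@H](N)C3)n(Cc3cc(F)ccc3C#N)c2=O)cc(Br)c1OC` - 3.49
- compound 3 `CC#CCn1c(N2CCC[C@@H](N)C2)cc(=O)n(CCCCCCCCCC)c1=O` - 3.82

In a physicochemical assay for lipophilicity (a higher number here means a more lipophilic compound, a lower number a more polar compound), compound 2 stands second highest of the three, at 3.49. Only compound 3 lies higher and compound 1 lies lowest, both gaps beyond the usual scatter.

Still unmeasured is compound 4 `CCCCCCn1c(=O)cc(N2CCC[C@@H](N)C2)n(Cc2cc(F)ccc2C#N)c1=O`. It differs from compound 2 as follows: pentyl in place of 3-bromo-4,5-dimethoxyphenyl on a saturated chain carbon bound to an aromatic nitrogen. Put briefly, 3-bromo-4,5-dimethoxybenzyl gives way to hexyl.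

Within the data shown here, no measured step makes this exact change. Among the measured compounds shown here, the one step available, a number 1.11 log units higher from compound 1 to compound 2 (beyond the scatter), is large but concerns the other substituent, which compound 4 keeps from compound 2. The nearest guide is a comparison of two values. Compound 3, with a decyl chain in the changing place, gives 3.82, while compound 1, with the substituted benzyl there, gives 2.38. Hexyl is shorter than decyl, however, and no measurement here shows what that shortening is worth.

A modest fall is therefore expected, and the estimated change is a number 0.39 log units lower from compound 2 to compound 4 (beyond the scatter).

Compound 4 is expected at 3.1, with an estimated range from 2.6 to 3.6.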

Compound 4, partition coefficient: 3.26
Beside the measured number, compound 4's estimate is 0.16 log units below it; low and high end bracket the measured number.
By their numbers in this assay, from the lowest: compound 1; then compounds 4 and 2 (each within the scatter of the next); then compound 3.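

In this assay, the exchange of 3-bromo-4,5-dimethoxybenzyl for hexyl gives a number 0.23 log units lower from compound 2 to compound 4 (within the scatter), so with the 2-cyano-5-fluorophenyl group kept in the other place, the two groups at this position cannot be told apart by this read-out. The change is a large one in structure, since pentyl, with no ring and no hydrogen-bond acceptors, replaces the ring-bearing, bromine- and oxygen-carrying 3-bromo-4,5-dimethoxyphenyl on a saturated chain carbon bound to an aromatic nitrogen, yet the number stays within the scatter. The earlier pair at this position, where compound 1 gives 2.38 and compound 3 gives 3.82, carried prop-1-yn-1-yl in the other place and a decyl chain rather than hexyl, and nothing available explains the new result.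

What the compounds shown leave open is how the number moves along the chain itself, for instance from a propyl to a hexyl to a decyl group on the same background. On these data alone, it is also open how a chain ending in an amine or a carboxylic acid would read at this position.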